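The compounds below may be only part of what the source reports. "The series", "measured", "known", "first", "only" and "open" are said of these compounds alone.

Compound 3 `O=C(NO)c1ccc(Cn2nnc(-c3ccc(C(F)(F)F)cc3)n2)cc1` sits second highest of the three numbers in an assay on Sf9 cells for inhibition of protein deacetylase HDAC6 (Homo sapiens), read by fluorescence (on this read-out lower numbers stand for stronger inhibition and higher numbers for weaker inhibition), with 11 nM. Compound 1 `Nc1ccc(-c2nnn(Cc3ccc(C(=O)NO)cc3)n2)cc1` gives 1 nM in this assay, and compound 2 `O=C(NO)c1ccc(Nc2nnc(-c3ccccc3)o2)cc1` gives 136 nM. For the measured compounds named here, the only measured step that touches compound 3 is an 11-fold higher number from compound 1 to compound 3 (1.04 log units; beyond the scatter). Compound 4 `O=C(NO)c1ccc(Cn2nnc(-c3ccc(S(F)(F)(F)(F)F)cc3)n2)cc1` differs from compound 3 by a group of 6 heavy atoms (5 fluorine, 1 sulfur; no ring) in place of a group of 4 heavy atoms (1 carbon, 3 fluorine; no ring), on an aromatic carbon. Going by the values given here, no measured pair shows this exchange, so the step from compound 1 to compound 3 offers only a loose guide, and a change within the scatter is expected, the step of a 1.4-fold higher number from compound 3 to compound 4 (0.13 log units; within the scatter) being the estimate. Compound 4 is therefore expected to give about 15 nM in this assay, within a range of 5 nM to 45 nM.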

Compound 4, half-maximal inhibitory concentration: 25 nM
Compound 4: the middle estimate sits 1.7-fold (0.22 log units) below what was measured, and the stated range covers the measured number.
By their numbers in this assay, from the lowest: compound 1; then compound 3; then compound 4; then compound 2.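

In this assay the aromatic carbon para to a large group responds even when trifluoromethyl gives way to another group with no hydrogen-bond donors, with a 2.3-fold higher number from compound 3 to compound 4 (0.36 log units; beyond the scatter) for this exchange. The amino group keeps the lowest number against this larger fluorinated group as well, with a 25-fold higher number from compound 1 to compound 4 (1.40 log units; beyond the scatter) across the whole exchange. Nothing given here accounts for either step.

As far as these compounds go, how a hydroxyl, a carboxylic acid or a dimethylamino group would read at this place stays open. So does whether the number keeps rising with heavy-atom count beyond these three groups.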